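This account rests on a few compounds, and the source may have more. Where it says the series, first, only, none or still open, it means among the compounds named here.

Compound 1 `Cc1ccccc1N1CCN(C2=CC(=O)c3cccc(O)c3C2=O)CC1`: 11000 nM
Compound 2 `O=C1C=C(N2CCC(c3ccccc3)CC2)C(=O)c2c(O)cccc21`: 11100 nM

Both compounds were tested in a functional assay on HT-1080 cells (Homo sapiens) for antiproliferative activity, read by MTT assay, with a stated time of 72 h; a lower number here means a stronger inhibitor, a higher number a weaker inhibitor. In this test compound 2 gives 11100 nM and compound 1 gives 11000 nM. For the measured compounds named here, these two numbers lie within the scatter of each other, so the pair cannot be ranked, and compound 2 stands level with the only other measured compound.

The next compound, compound 3 `O=C1C=C(N2CCC(c3ccc(Cl)cc3)CC2)C(=O)c2c(O)cccc21`, has not been measured yet. It differs from compound 2 in a single place: chloro in place of hydrogen on an aromatic carbon. In words, this is chloro in place of hydrogen on an aromatic carbon, which turns phenyl into 4-chlorophenyl.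

Going by the values given here, no two measured compounds differ in just one place, so the data show no measured step to serve as a guide. A change this small is expected to give only a modest shift toward a lower number, meaning a somewhat stronger inhibitor, and it may not clear the scatter. The expected size of a 1.6-fold lower number from compound 2 to compound 3 (0.20 log units; within the scatter) is therefore small. For compound 3 the estimate is 7000 nM, with an expected range from 2500 nM to 16000 nM.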

Compound 3, half-maximal inhibitory concentration: 22400 nM
Compound 3: middle estimate off by 3.2-fold (0.51 log units), on the low side, and the stated range ends below it.
By their numbers in this assay, from the lowest: compounds 1, 2 and 3 (each within the scatter of the next, the first and the last beyond it).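

In this assay, placing a chloro group on the aromatic carbon para to a large group, which turns phenyl into 4-chlorophenyl, gives a 2.0-fold higher number from compound 2 to compound 3 (0.30 log units; within the scatter). For the compounds shown here, this is the first measured comparison of two compounds that differ in only one place, and it lies within the scatter, so compound 2 and compound 3 cannot be ranked and this single change shows no clear effect on the read-out, in either direction. No measurement shown here offers an explanation for the value of compound 3.

What the compounds shown leave open is whether a different group on this same aromatic carbon, such as fluoro, methoxy, an amine or a carboxylic acid, would produce a step that clears the scatter. A single pair also cannot say whether chloro would give a similar result on another compound in the series, so no general rule about this change can be drawn yet.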